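From Nitro to Methoxy: an Expected Gain in Growth Inhibition

The source may hold more compounds than are shown below. What is called first, only, known or untested is meant among the compounds shown, and "the series" means these compounds.

Three compounds have been measured in a functional assay on A-375 cells (Homo sapiens) for antiproliferative activity, read by MTT assay, with a stated time of 48 h (a lower number here means a stronger inhibitor of growth, a higher number a weaker inhibitor of growth), and their numbers are:

Compound 1, `S=C(Nc1ccccc1)N1N=C(c2ccc(Br)cc2)CC1c1ccc2c(c1)OCCO2`, gives 470 nM
Compound 2, `Cc1ccc(C2=NN(C(=S)Nc3ccccc3)C(c3ccc4c(c3)OCCO4)C2)cc1`, gives 6320 nM
Compound 3, `O=[N+]([O-])c1ccc(C2=NN(C(=S)Nc3ccccc3)C(c3ccc4c(c3)OCCO4)C2)cc1`, gives 78100 nM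

Compound 3 stands highest of the three and is the weakest inhibitor of growth. Among the measured compounds shown here, the steps that bear on the present change were a 170-fold higher number from compound 1 to compound 3 (2.22 log units; beyond the scatter) and a 12-fold higher number from compound 2 to compound 3 (1.09 log units; beyond the scatter), both large.

Compound 4, `COc1ccccc1C1=NN(C(=S)Nc2ccccc2)C(c2ccc3c(c2)OCCO3)C1`, differs from compound 3 by 2-methoxyphenyl in place of 4-nitrophenyl on a carbon with a double bond to nitrogen. Both measured steps show that the nitro group goes with a far higher number than bromo or methyl, so removing it is expected to lower the number. For the measured compounds named here, no measured compound carries a methoxy group or a 2-methoxyphenyl group, so the size of the step is uncertain. Compound 4 is therefore expected to give about 3000 nM, within a range from 500 nM to 20000 nM. That amounts to an expected step of a 26-fold lower number from compound 3 to compound 4 (1.42 log units; beyond the scatter).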

Compound 4, concentration for 50% growth inhibition: 20300 nM
Compound 4: middle estimate off by 6.8-fold (0.83 log units), on the low side, outside the stated range (above it).
By their numbers in this assay, from the lowest: compound 1; then compound 2; then compound 4; then compound 3.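

In this assay, exchanging 4-nitrophenyl for 2-methoxyphenyl gives only a modest gain (a 3.8-fold lower number from compound 3 to compound 4 (0.59 log units; beyond the scatter)), so losing the nitro group does not by itself bring the number down to those of the bromo and methyl compounds. The 2-methoxyphenyl group still trails 4-methylphenyl modestly (a 3.2-fold higher number from compound 2 to compound 4 (0.51 log units; beyond the scatter)) and 4-bromophenyl by a large margin (a 43-fold higher number from compound 1 to compound 4 (1.64 log units; beyond the scatter)). Nothing measured here explains this order.

The 2-methoxyphenyl group differs from the others in both its substituent and that substituent's ring position, and these two changes cannot be separated here. A 4-methoxyphenyl group at this position would tell them apart.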